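Removing the para-chloro from the benzamide of compound 3

The source may report more compounds than this note shows. Statements on the series, on what has been measured and on what is new or still open speak of the compounds shown alone.

Of the compounds shown here, three sharing one core have been measured in a functional assay on SK-MEL-28 cells (Homo sapiens) for cytotoxicity, read by MTT assay; on this read-out lower numbers stand for stronger inhibition and higher numbers for weaker inhibition. Compound 1 `O=S(=O)(NCCCNc1nccc(-c2c(-c3cccc(F)c3)nc3sccn23)n1)c1ccc(F)cc1` reaches only a limit of the assay, giving > 20000 nM; of the three values shown, one is such a limit (the limit of > 20000 nM in this assay, at which 1 of the 3 values shown sits). Compound 2 `O=S(=O)(NCCNc1nccc(-c2c(-c3cccc(F)c3)nc3sccn23)n1)c1ccc(F)cc1` gives 9450 nM, and compound 3 `O=C(NCCNc1nccc(-c2c(-c3cccc(F)c3)nc3sccn23)n1)c1ccc(Cl)cc1` gives 8160 nM, the lowest number among the two measured values, though its difference from compound 2 is within the scatter. The step of an at least 2.1-fold lower number from compound 1 to compound 2 (0.32 log units; beyond the scatter) and the step of an at least 2.4-fold lower number from compound 1 to compound 3 (0.38 log units; beyond the scatter) both shorten the chain, while the step of a 1.2-fold lower number from compound 2 to compound 3 (0.06 log units; within the scatter) swaps the sulfonyl group for a carbonyl group and stays within the scatter.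

Compound 4 `O=C(NCCNc1nccc(-c2c(-c3cccc(F)c3)nc3sccn23)n1)c1ccccc1` differs from compound 3 only by hydrogen in place of chloro on an aromatic carbon. Among the measured compounds shown here, no measured step removes a halogen from this aromatic ring, so the nearest guide is the step from compound 2 to compound 3, which stays within the scatter. A change of similar or slightly weakening size is therefore expected, a 1.3-fold higher number from compound 3 to compound 4 (0.13 log units; within the scatter), in this assay. Compound 4 is estimated at 11000 nM, expected to lie between 4500 nM and 25000 nM.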

Compound 4, half-maximal inhibitory concentration: 17000 nM
Compound 4: middle estimate off by 1.5-fold (0.19 log units), on the low side; low and high end bracket the measured number.
By their numbers in this assay, from the lowest: compounds 3, 2 and 4 (each within the scatter of the next, the first and the last beyond it). At a limit, above all of these: compound 1.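

In this assay, taking the chloro off the benzoyl ring gives a 2.1-fold higher number from compound 3 to compound 4 (0.32 log units; beyond the scatter), so at this place on the ring, 4-chlorophenyl and phenyl can be told apart, if only modestly. Replacing the whole (4-fluorophenyl)sulfonyl group with benzoyl gives a 1.8-fold higher number from compound 2 to compound 4 (0.26 log units; within the scatter), which stays within the scatter, so this small edit to the benzamide separates two compounds more clearly than that larger swap does. Compound 1 stands at a limit of the assay, so its step to compound 4, an at least 1.1-fold lower number from compound 1 to compound 4 (0.07 log units; that floor lies within the scatter), cannot be read: the limit of > 20000 nM in this assay, at which 1 of the 4 values shown sits.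

Going by these compounds, whether this difference belongs to chlorine in particular or would appear with any other group at this place remains open. A fluoro, methyl or methoxy group on the same ring carbon would help to separate these two readings.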